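A Hydroxy for Methoxy Swap on a Shared Macrocyclic Core

The source may report more compounds than this note shows. Statements on the series, on what has been measured and on what is new or still open speak of the compounds shown alone.

Three compounds built on one core were examined in a functional assay on Daoy cells (Homo sapiens) for cytotoxicity, read by MTT assay; on this read-out lower numbers stand for stronger inhibition and higher numbers for weaker inhibition. For the measured compounds named here, compound 1 `C=C1CC[C@@H]2CC[C@H](OC(=O)C/C(C)=C/[C@@H](O)C1)C(=O)C2(C)C` is the first of them; in this assay compound 1 gives > 20 ug/mL, which is a limit of the assay rather than a number. Compound 2 `C=C1CC[C@@H]2CCC3=C(C2(C)C)[C@@](OC)(C/C(C)=C/[C@@H](O)C1)OC3=O` carries a methoxy group on a saturated carbon of the shared core; in this assay compound 2 gives > 20 ug/mL, again only a limit. Compound 3 `C=C1CC[C@@H]2CCC3=C(C(=O)[C@@H](/C(C)=C/[C@@H](OC(C)=O)C1)[C@H]3O)C2(C)C` is the third; in this assay compound 3 gives > 20 ug/mL, likewise a limit. Compound 2 thus stands at the limit of > 20 ug/mL in this assay, at which 3 of the 3 values shown sit, and on the numbers shown nothing separates it from compound 1 or compound 3, since all three are limits.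

Compound 4 `C=C1CC[C@@H]2CCC3=C(C2(C)C)[C@@](O)(C/C(C)=C/[C@@H](O)C1)OC3=O` differs from compound 2 in one place: hydrogen in place of methyl on an oxygen on a saturated carbon. Cut one bond further out, the change reads methoxy to hydroxy, on an oxygen on a saturated carbon whose other neighbours are a saturated ring carbon. Going by the values given here, no step between measured compounds is available to weigh such a change. Because compound 2 sits at the limit of > 20 ug/mL in this assay, at which 3 of the 3 values shown sit, and every measured compound shares that limit, the step from compound 2 to compound 4 is expected to be a step that the limit leaves unreadable from compound 2 to compound 4, with no direction beyond the scatter foreseen. Compound 4 is therefore estimated at 30 ug/mL, between 10 ug/mL and 100 ug/mL, and a limit rather than a number is the most likely report.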

Compound 4, half-maximal inhibitory concentration: > 20 ug/mL
Compound 4: only a limit was reported; the forecaster's own chance of this, stated with the estimate: 80%; the middle value lies beyond the limit too.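

In this assay compound 4 gives > 20 ug/mL, which is a limit and not a number. For the compounds shown here, compound 2 also has only a limit, so no step between compound 2 and compound 4 can be read: the limit of > 20 ug/mL in this assay, at which 4 of the 4 values shown sit. The compounds shown leave open whether the change from methoxy to hydroxy has any effect in this assay.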